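Compound 2 to compound 3: methyl replaced by hydrogen

The source may report more compounds than this note shows. Statements on the series, on what has been measured and on what is new or still open speak of the compounds shown alone.

Measured so far in a functional assay on MV4-11 cells (Homo sapiens) for inhibition, read by resazurin assay, with a stated time of 72 h; a lower number here means a stronger inhibitor of growth, a higher number a weaker inhibitor of growth
- compound 1 `O=C(Nc1cccc(CN2CCCC2)c1)c1n[nH]c2ccccc12` gives 8620 nM as a number
- compound 2 `Cc1ccccc1Nc1ncc2c(n1)CCCC2` gives > 10000 nM as a limit

Compound 2 stands at the limit of this assay, with > 10000 nM as its entry, which is a limit and not a number. Among the compounds with values here, compound 1 does not share the core of compound 2, and no measured pair here isolates a single change, so its value offers no direct guide to the next step.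

Compound 3 `c1ccc(Nc2ncc3c(n2)CCCC3)cc1` keeps the shared core of compound 2 and changes in one place only: hydrogen in place of methyl on an aromatic carbon. The change is hydrogen in place of methyl on an aromatic carbon, ortho to a large group.

Within the data shown here, with no measured step to draw on, no change beyond the scatter is expected in this assay, in either direction. The expected step is a step that the limit leaves unreadable from compound 2 to compound 3, and this is an estimate only. A report of compound 3 as a limit as well would fit this expectation. The estimated value for compound 3 is 13000 nM (5000 nM to 30000 nM) in this assay as the expected range.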

Compound 3, concentration for 50% growth inhibition: 9830 nM
Compound 3: middle estimate off by 1.3-fold (0.12 log units), on the high side; the range from low to high includes it.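

In this assay, hydrogen in place of methyl on an aromatic carbon, ortho to a large group, gives an at least 1.0-fold lower number from compound 2 to compound 3 (0.00 log units; that floor lies within the scatter), a step bounded on one side only. Compound 2 gives > 10000 nM, which is a limit and not a number, so the true size of this step cannot be read: the limit of > 10000 nM in this assay, at which 1 of the 3 values shown sits.

Within the data shown here, compound 3 gives 9830 nM, the first actual number for the shared core, and it offers a measured reference for later changes at this position that compound 2 could not provide.

The compounds shown leave open whether the methyl changes growth inhibition at all, since a step within the scatter and a larger one both fit the bound. They also leave open how this aromatic carbon responds to other groups, such as a methoxy group, a chlorine atom or an amine, and whether any substituent there moves the value beyond the scatter from that of compound 3.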